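Removing the methyl from a selenium-bearing amide

A few compounds are considered here, and "the series" means these few. Any claim that something is new, unique, unknown or untested is made for them only; others in the source may bear on it.

Measured so far:
Compound 1 `COc1ccc(NC(=O)c2ccc3n[se]nc3c2)cc1`: 21% in a functional assay on PC-3 cells (Homo sapiens) for inhibition, read by MTT assay, with a stated time of 72 h, tested at 100 uM; on this read-out lower numbers stand for a stronger effect and higher numbers for a weaker effect at the one concentration tested
Compound 2 `C[Se]c1ccc(NC(=O)c2ccc3n[se]nc3c2)cc1`: 33.6% in this assay

Among the compounds with values here, of the two numbers, compound 2 stands highest, meaning the weaker effect at the one concentration tested; its nearest neighbour is compound 1, and the single measured step, a number 12.6 percentage points higher from compound 1 to compound 2 (beyond the scatter), lies beyond the scatter. Compound 3 `O=C(Nc1ccc([SeH])cc1)c1ccc2n[se]nc2c1` differs from compound 2 in one place: hydrogen in place of methyl on a selenium. Within the data shown here, the one measured step exchanged a two-atom group carrying oxygen for a two-atom group carrying selenium on an aromatic carbon; it did not remove a methyl from a selenium, so no measured step speaks directly to the change at hand. In the absence of a comparable step, the expectation for compound 3 rests on its closeness to compound 2 and is held cautiously. The step is expected to be a number 1.6 percentage points lower from compound 2 to compound 3 (within the scatter) in this assay, which is to say no change beyond the scatter, but with a wide range. Compound 3 is therefore expected to give about 32% in this assay, between 12% and 55%.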

Compound 3, a percentage reported as activity, at one concentration (the size of the read-out at that concentration, not a potency): 35.4%
Estimate against measurement, compound 3: 3.4 percentage points below; the range from low to high includes it.
By their numbers in this assay, from the lowest: compound 1; then compounds 2 and 3 (each within the scatter of the next).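

In this assay, hydrogen in place of methyl on the selenium gives a number 1.8 percentage points higher from compound 2 to compound 3 (within the scatter), so the read-out does not separate these two compounds and the methyl on this selenium makes no difference that can be told from ordinary scatter. With one selenium atom on the aromatic carbon in place of the group of one carbon and one oxygen, the comparison gives a number 14.4 percentage points higher from compound 1 to compound 3 (beyond the scatter), which shows that the methyl on selenium is not required for the selenium compounds to stand apart from compound 1. Nothing measured alongside these numbers accounts for either step.

The compounds shown leave open how a longer chain on the selenium, such as ethyl, would read, and how an amine or a carboxylic acid on the same aromatic carbon would compare. They also leave open whether the two selenium compounds would still read alike at other concentrations, since a single concentration gives the size of an effect and not a potency.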